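This account rests on a few compounds, and the source may have more. Where it says the series, first, only, none or still open, it means among the compounds named here.

Measured so far:
- compound 1, `O=C(Nc1ccc(Oc2ccnc3[nH]ccc23)cc1)c1cn(-c2ccc(F)c(Cl)c2)c2ccccc2c1=O`: 1120 nM
- compound 2, `COc1ccc(-n2cc(C(=O)Nc3ccc(Oc4ccnc5[nH]ccc45)cc3)c(=O)c3ccccc32)cc1`: 5950 nM
- compound 3, `Cn1ccc2c(Oc3ccc(NC(=O)c4cn(-c5ccc(F)c(Cl)c5)c5ccccc5c4=O)cc3F)ccnc21`: recorded as "not determined" (no result reported)

In a functional assay on HepG2 cells (Homo sapiens) for inhibition, read by MTT assay, with a stated time of 72 h (a higher number here means a weaker inhibitor, a lower number a stronger inhibitor), compound 1 gives 1120 nM, and compound 2 gives 5950 nM. The two differ in one place: 4-methoxyphenyl in place of 3-chloro-4-fluorophenyl on an aromatic nitrogen. That change produced a 5.3-fold higher number from compound 1 to compound 2 (0.73 log units; beyond the scatter), a loss of potency that is beyond the usual scatter.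

Compound 3, `Cn1ccc2c(Oc3ccc(NC(=O)c4cn(-c5ccc(F)c(Cl)c5)c5ccccc5c4=O)cc3F)ccnc21`, carries the same 3-chloro-4-fluorophenyl group as compound 1 but on a different core; the difference between the two cores is not broken down here, and for compound 3 no result is reported in this assay. Compound 4, `COc1ccc(-n2cc(C(=O)Nc3ccc(Oc4ccnc5c4ccn5C)c(F)c3)c(=O)c3ccccc32)cc1`, is not yet measured. It relates to compound 3 as compound 2 relates to compound 1: 4-methoxyphenyl in place of 3-chloro-4-fluorophenyl on an aromatic nitrogen. The surroundings of the change are the same in both pairs, so this is the same change, made on the other core.

Because compound 2 gives 5950 nM, and because the same change in the measured pair gave a 5.3-fold higher number from compound 1 to compound 2 (0.73 log units; beyond the scatter), compound 4 is expected to be a weak inhibitor in this assay, around 8000 nM, with a plausible range from 2000 nM to 30000 nM. Without a value for compound 3, this estimate rests on compound 2 alone.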

Compound 4, half-maximal inhibitory concentration: 3750 nM
Compound 4: the middle estimate sits 2.1-fold (0.33 log units) above what was measured; the range from low to high includes it.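

Compound 3 has no number in this assay to set against compound 4, so no new step can be read from this result. The compounds shown leave open whether swapping 3-chloro-4-fluorophenyl for 4-methoxyphenyl has the same effect on the core of compound 3 as on the core of compound 1. No evidence here bears on the value of compound 4.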